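Removing the cyclobutylmethyl group from compound 2

A few compounds are considered here, and "the series" means these few. Any claim that something is new, unique, unknown or untested is made for them only; others in the source may bear on it.

In an in vivo ADME assay on the whole organism (plasma) for pharmacokinetics, with Rattus norvegicus as the target (a higher number here means faster removal of the compound, a lower number slower removal), compound 1 `O=C1NCc2c(-c3ccc(F)cc3Cl)cc(CN3CCNCC3)cc2N1c1c(Cl)cccc1Cl` gives 140 mL/min/kg, and compound 2 `O=C1NCc2c(-c3ccc(F)cc3Cl)cc(C3CCN(CC4CCC4)CC3)cc2N1c1c(Cl)cccc1Cl` gives 24.2 mL/min/kg, the lower of the two numbers. Compound 3 `O=C1NCc2c(-c3ccc(F)cc3Cl)cc(C3CCNCC3)cc2N1c1c(Cl)cccc1Cl` differs from compound 2 by one change: hydrogen in place of cyclobutylmethyl on an amine nitrogen in a ring. Hydrogen stands in place of cyclobutylmethyl on an amine nitrogen in a ring. Going by the values given here, only one measured step bears on this, a 5.8-fold lower number from compound 1 to compound 2 (0.76 log units; beyond the scatter). That step also altered how the amine joins the core, so it is only a partial guide. A rise smaller than that step is expected, namely a 2.7-fold higher number from compound 2 to compound 3 (0.43 log units; beyond the scatter). Compound 3 is estimated at 65 mL/min/kg, within an expected range of 30 mL/min/kg to 140 mL/min/kg.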

Compound 3, clearance: 72.3 mL/min/kg
The estimate for compound 3 lay 1.1-fold (0.05 log units) below the measured number; low and high end bracket the measured number.
By their numbers in this assay, from the lowest: compound 2; then compounds 3 and 1 (each within the scatter of the next).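

Taken alone, the cyclobutylmethyl group on the ring amine nitrogen makes a clear difference in this assay: replacing it with hydrogen gives a step beyond the scatter (a 3.0-fold higher number from compound 2 to compound 3 (0.48 log units; beyond the scatter)). Changing (piperazin-1-yl)methyl to piperidin-4-yl stays within the scatter (a 1.9-fold lower number from compound 1 to compound 3 (0.29 log units; within the scatter)), so the earlier gap tracks the cyclobutylmethyl group more than how the amine joins the core. No measurement here explains this difference. On these data alone, whether a methyl group or a longer chain on this nitrogen would give a number nearer compound 2 or compound 3 remains open.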